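The compounds below may be only part of what the source reports. "The series", "measured", "known", "first", "only" and "open" are said of these compounds alone.

Compound 1 `O=C(Nc1ccc(Oc2ccnc3[nH]ccc23)c(F)c1)c1nn(-c2ccc(Cl)c(F)c2)ccc1=O`: 13600 nM
Compound 2 `Cc1cc(=O)n(-c2ccc(F)cc2)nc1C(=O)Nc1ccc(Oc2ncnc3[nH]ccc23)cc1`: > 60000 nM
Compound 3 `Cc1cc(=O)n(-c2ccc(F)cc2)nc1C(=O)Nc1ccc(Oc2ncnc3[nH]ccc23)c(F)c1`: 17300 nM

In a functional assay on PC-3 cells (Homo sapiens) for cytotoxicity, read by MTT assay, with a stated time of 72 h (a lower number here means a stronger inhibitor, a higher number a weaker inhibitor), compound 1 gives 13600 nM. For compound 2 the result is only a limit of the assay, > 60000 nM (the limit of > 60000 nM in this assay, at which 1 of the 3 values shown sits). Compound 3 gives 17300 nM in this assay, the higher of the two numbers, with compound 1 within the scatter of it. Going by the values given here, the one measured step is an at least 3.4-fold lower number from compound 2 to compound 3 (0.54 log units; beyond the scatter).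

Compound 4 `Cc1cc(=O)n(-c2cccc(C(F)(F)F)c2)nc1C(=O)Nc1ccc(Oc2ncnc3[nH]ccc23)c(F)c1` differs from compound 3 by 3-(trifluoromethyl)phenyl in place of 4-fluorophenyl on an aromatic nitrogen. Among the compounds with values here, no measured step alters the group on that ring nitrogen, so nothing here sets a direction. Compound 4 is therefore expected near compound 3, estimated at 17000 nM, between 5000 nM and 60000 nM. The expected step from compound 3 is a 1.0-fold lower number from compound 3 to compound 4 (0.01 log units; within the scatter), not beyond the scatter.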

Compound 4, half-maximal inhibitory concentration: 15600 nM
Estimate against measurement, compound 4: 1.1-fold (0.04 log units) above; the range from low to high includes it.
By their numbers in this assay, from the lowest: compounds 1, 4 and 3 (each within the scatter of the next). At a limit, above all of these: compound 2.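

In this assay, replacing the group on the ring nitrogen gives a 1.1-fold lower number from compound 3 to compound 4 (0.04 log units; within the scatter) and so shows that this position accepts 3-(trifluoromethyl)phenyl in place of 4-fluorophenyl, a group with more heavy atoms, without a change beyond the scatter. This is the first step shown at this position, as the earlier step concerned a fluoro elsewhere in the molecule. Nothing available here gives a reason for this result.

Still open, on these data alone, is how this position responds to a group other than a substituted phenyl, such as a plain alkyl chain or a phenyl carrying an amine or a carboxylic acid. Also open, as far as these compounds go, is whether 3-(trifluoromethyl)phenyl behaves the same way on the core of compound 1.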